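Swapping an ethyl for a fluorophenyl on a thiourea

The compounds below may be only part of what the source reports. "The series", "measured", "known", "first", "only" and "open" are said of these compounds alone.

Measured so far in an ADME assay on BHK cells (Mesocricetus auratus) for cytotoxicity, read by MTT assay, with a stated time of 96 h; a higher number here means that more compound is tolerated, a lower number that less compound is tolerated:
compound 1, `CCNC(=S)Nc1cccc(C(F)(F)F)c1`: > 100000 nM, a limit of the assay and not a number
compound 2, `CCCCc1ccc(NC(=S)Nc2cccc(C(F)(F)F)c2)c(C)c1`: 9000 nM
compound 3, `Cc1ccc(NC(=S)Nc2cccc(C(F)(F)F)c2)cc1Cl`: 10000 nM

Compound 1 stands at the limit of > 100000 nM in this assay, at which 1 of the 3 values shown sits; for it only this limit is known, no exact concentration. Compound 2 and compound 3 each carry an aromatic ring on the thiourea nitrogen, and their two values sit within the usual scatter of each other, so no order between them can be read.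

Compound 4, `Fc1ccc(NC(=S)Nc2cccc(C(F)(F)F)c2)cc1`, has not yet been tested in this assay. It differs from compound 1 in one place: 4-fluorophenyl in place of ethyl on an amide-type nitrogen. Within the data shown here, no directly comparable pair of measured compounds exists for this change, so the size of the step can only be guessed from the other two compounds.

A large step downward in this assay is expected for compound 4 because compound 2 gives 9000 nM and compound 3 gives 10000 nM, both with an aromatic ring in the same place. Compound 4 is therefore estimated at 15000 nM, with a likely range from 5000 nM to 60000 nM. The expected step is an at least 6.6-fold lower number from compound 1 to compound 4 (0.82 log units; beyond the scatter).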

Compound 4, half-maximal cytotoxic concentration: 26000 nM
The estimate for compound 4 lay 1.7-fold (0.24 log units) below the measured number, within the range that was stated.
By their numbers in this assay, from the lowest: compounds 2 and 3 (each within the scatter of the next); then compound 4. At a limit, above all of these: compound 1.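

In this assay, among these compounds, this is the first comparison in which only one place changes: 4-fluorophenyl in place of ethyl on the amide-type nitrogen gives an at least 3.8-fold lower number from compound 1 to compound 4 (0.58 log units; beyond the scatter) for this single swap. On this nitrogen, then, the aromatic group goes with less compound being tolerated, which compound 2 and compound 3 could not show, since neither differs from compound 1 in just one place. The full size of the step stays unknown, because compound 1 stands at a limit of the assay and not at a number: the limit of > 100000 nM in this assay, at which 1 of the 4 values shown sits.

Still open is whether the ring alone accounts for the step or whether the fluorine on it plays a part, as no plain phenyl stands among these compounds. Also open, on these data alone, is how a longer chain such as hexyl, or a chain ending in an amine, would behave in place of ethyl.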